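The compounds below may be only part of what the source reports. "The series", "measured", "known", "first", "only" and "open" are said of these compounds alone.

Compound 3 `Oc1ccc(-c2cc(-c3ccccc3C(F)(F)F)cc(-c3ccc(O)cc3)n2)cc1` sits at the edge of what a functional assay on DU-145 cells (Homo sapiens) for inhibition (on this read-out higher numbers stand for weaker inhibition and lower numbers for stronger inhibition), can report: its result of > 50000 nM is a limit of the measurement, not a number. Among the compounds that do give numbers, compound 1 `Oc1ccc(-c2cc(-c3ccccc3F)cc(-c3ccc(O)cc3)n2)cc1` gives 7780 nM in this assay, and compound 2 `Oc1ccc(-c2cc(-c3cccc(C(F)(F)F)c3)cc(-c3cccc(O)c3)n2)cc1` gives 11100 nM. Compound 4 `Oc1ccc(-c2cc(-c3cccc(C(F)(F)F)c3)cc(-c3ccc(O)cc3)n2)cc1` has not yet been measured. It differs from compound 3 in one place (3-(trifluoromethyl)phenyl in place of 2-(trifluoromethyl)phenyl on an aromatic carbon), that is, 3-(trifluoromethyl)phenyl in place of 2-(trifluoromethyl)phenyl on an aromatic carbon.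

Going by the values given here, only one measured step touches this part of the molecule: an at least 6.4-fold higher number from compound 1 to compound 3 (0.80 log units; beyond the scatter), in which trifluoromethyl replacing fluoro took the number to the limit of > 50000 nM in this assay, at which 1 of the 3 values shown sits. That step says how compound 3 came to be unmeasurable, but it does not directly tell what moving the trifluoromethyl does. Among the compounds with values here, compound 2 carries the same 3-(trifluoromethyl)phenyl that compound 4 will carry, and its value lies well inside the measurable range, though compound 2 also differs from compound 4 elsewhere, so no single-point step joins the two.

On this basis compound 4 is expected to return to a measurable number, about 12000 nM, with a plausible range from 4000 nM to 40000 nM. This estimate corresponds to an at least 4.1-fold lower number from compound 3 to compound 4 (0.61 log units; beyond the scatter), a step toward stronger inhibition.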

Compound 4, half-maximal inhibitory concentration: > 50000 nM
Compound 4: a limit, no number; the forecaster's own chance of this, stated with the estimate: 15%; middle value at least 4.1-fold (0.61 log units) from the limit.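

The step between compound 3 and compound 4 cannot be read, and the shift of the trifluoromethyl from 2-(trifluoromethyl)phenyl to 3-(trifluoromethyl)phenyl brings back no number in this assay, because both results are limits: the limit of > 50000 nM in this assay, at which 2 of the 4 values shown sit.

What can be read lies elsewhere. Putting 4-hydroxyphenyl in place of 3-hydroxyphenyl gives an at least 4.5-fold higher number from compound 2 to compound 4 (0.65 log units; beyond the scatter), so with 3-(trifluoromethyl)phenyl opposite the ring nitrogen, the change between these two hydroxyphenyl groups decides whether a number appears at all. Going by these compounds alone, putting 3-(trifluoromethyl)phenyl in place of 2-fluorophenyl gives an at least 6.4-fold higher number from compound 1 to compound 4 (0.80 log units; beyond the scatter), which leaves compound 1 as the only compound with two 4-hydroxyphenyl groups to give a number here.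

Still open, from the compounds shown here alone, is whether 3-fluorophenyl, or a phenyl group carrying an amine or a carboxylic acid, on this same carbon would give a number alongside two 4-hydroxyphenyl groups. Also open, going by these compounds, is whether 3-hydroxyphenyl in place of one 4-hydroxyphenyl would give a number with 2-(trifluoromethyl)phenyl as well, as it does with 3-(trifluoromethyl)phenyl in compound 2.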